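A pyridyl variant of compound 2 in the cell assay

The source may hold more compounds than are shown below. What is called first, only, known or untested is meant among the compounds shown, and "the series" means these compounds.

Compound 1 `C=CC[C@H]1C[C@]2([C@@H](C)Cc3cccc(OC)c3)OCOC2=CC1=O`: 8800 nM
Compound 2 `C=CC[C@H]1C[C@]2([C@@H](C)Cc3ccccc3)OCOC2=CC1=O`: 5100 nM
Compound 3 `C=CC[C@H]1C[C@]2([C@@H](C)Cc3ccc(OC(F)(F)F)cc3)OCOC2=CC1=O`: > 20000 nM

Three analogues sharing one core have been tested in a functional assay on M14 cells (Homo sapiens) for antiproliferative activity, with a stated time of 72 h; on this read-out higher numbers stand for weaker inhibition and lower numbers for stronger inhibition. Compound 2 has the lowest of the two plain numbers, and its nearest neighbour is compound 1, with a step of a 1.7-fold lower number from compound 1 to compound 2 (0.24 log units; within the scatter). Compound 3 gives only a limit of the assay, > 20000 nM, and so no number. For the measured compounds named here, the step of an at least 3.9-fold higher number from compound 2 to compound 3 (0.59 log units; beyond the scatter) is the one change here that moves the read-out beyond the scatter.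

The untested compound 4 `C=CC[C@H]1C[C@]2([C@@H](C)Cc3ccc(OC)nc3)OCOC2=CC1=O` differs from compound 2 in one place: 6-methoxypyridin-3-yl in place of phenyl on a saturated chain carbon, two bonds along the chain from a saturated ring carbon. Going by the values given here, two measured steps bear on this. Removing a methoxy from the aromatic ring, in the step from compound 1 to compound 2, stayed within the scatter, while adding a trifluoromethoxy, in the step from compound 2 to compound 3, weakened the read-out at least modestly. Compound 4 adds a methoxy together with a ring nitrogen, a larger change than either. A small to modest rise in the number is therefore expected for compound 4, a 1.6-fold higher number from compound 2 to compound 4 (0.20 log units; within the scatter). The estimate for compound 4 in this assay is 8000 nM, with a likely range from 3000 nM to 20000 nM.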

Compound 4, half-maximal inhibitory concentration: 180 nM
For compound 4 the middle estimate is 44-fold (1.65 log units) above the measured one; measured number below the stated range.
By their numbers in this assay, from the lowest: compound 4; then compounds 2 and 1 (each within the scatter of the next). At a limit, above all of these: compound 3.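

In this assay the aromatic group on this saturated chain carbon proves able to move the read-out strongly: the change to 6-methoxypyridin-3-yl gives a 28-fold lower number from compound 2 to compound 4 (1.45 log units; beyond the scatter), and set against the 3-methoxyphenyl group it gives a 49-fold lower number from compound 1 to compound 4 (1.69 log units; beyond the scatter). For the compounds shown here, the earlier compounds showed this ring only as changes within the scatter or as a loss of strength, so this is the first large gain at this place, and the methoxy of compound 1 on a ring of carbon only gives nothing comparable. Nothing measured in the data shown accounts for the size of this gain.

Going by these compounds alone, the ring nitrogen and the methoxy enter together in compound 4, so it remains open whether one of them alone or only the pair carries the gain, a question that a plain pyridin-3-yl group on the same chain carbon would address. Also open, going by these compounds, is how much the methoxy on the pyridine ring can be altered, for instance to an ethoxy, a hydroxyl or an amine, and whether the gain would survive such a swap.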